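The source may hold more compounds than are shown below. What is called first, only, known or untested is meant among the compounds shown, and "the series" means these compounds.

Measured compounds:
Compound 1 `COc1ccc(NC(=O)CSC(=S)N[C@H]2CCOC2=O)cc1`: in a functional assay on EC9706 cells (Homo sapiens) for cytotoxicity, read by MTT assay, with a stated time of 72 h (on this read-out lower numbers stand for stronger inhibition and higher numbers for weaker inhibition), compound 1 gives > 128000 nM, which is a limit of the assay and not a number.
Compound 2 `O=C(CCl)Nc1ccc(C(=O)/C=C/c2ccccc2)cc1`: in this assay compound 2 gives 6370 nM.

Among the measured compounds shown here, compound 2 therefore stands on the only number that this assay gives here; the other result is a limit, as the limit of > 128000 nM in this assay, at which 1 of the 2 values shown sits, records. Compound 3 `O=C(CSC(=S)N[C@H]1CCOC1=O)Nc1ccc(C(=O)/C=C/c2ccccc2)cc1` has not yet been measured in this assay. It differs from compound 2 by a group of 10 heavy atoms (5 carbon, 1 nitrogen, 2 oxygen, 2 sulfur; one five-membered non-aromatic ring with 1 hetero atom) in place of one chlorine atom, on a saturated chain carbon bound to a carbonyl carbon, so that compound 3 carries both the carbonyl-linked chain of compound 2 and the five-membered lactone with its dithiocarbamate found in compound 1. For the measured compounds named here, no step between measured compounds is available to set the size of this change. Compound 3 is expected to sit weaker than compound 2, with a step of a 2.4-fold higher number from compound 2 to compound 3 (0.37 log units; beyond the scatter) beyond the usual scatter. The estimate for compound 3 in this assay is 15000 nM, within a range from 4000 nM to 60000 nM.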

Compound 3, half-maximal inhibitory concentration: 44900 nM
The estimate for compound 3 lay 3.0-fold (0.48 log units) below the measured number; low and high end bracket the measured number.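

In this assay, placing the lactone-bearing dithiocarbamate group instead of the chloro group on the saturated chain carbon bound to a carbonyl carbon gives a 7.0-fold higher number from compound 2 to compound 3 (0.85 log units; beyond the scatter), so this position tolerates the new group, but at a measurable loss of activity. With that same group present in both compounds, (2-phenylethenyl)carbonyl in place of methoxy on an aromatic carbon gives an at least 2.8-fold lower number from compound 1 to compound 3 (0.45 log units; beyond the scatter), which shows that the change on the aromatic carbon lowers the number. That step rests on compound 1, whose result is a limit of the assay and not a number: the limit of > 128000 nM in this assay, at which 1 of the 3 values shown sits.

The compounds shown hold only these two groups at the chain carbon, so they leave open whether the rise comes from losing the chloro group or from the group that enters. An amine at that carbon, or an open-chain dithiocarbamate without the lactone ring, would help separate these readings.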